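A few compounds are considered here, and "the series" means these few. Any claim that something is new, unique, unknown or untested is made for them only; others in the source may bear on it.

Measured in a functional assay on MKN-45 cells (Homo sapiens) for inhibition, with a stated time of 72 h; a higher number here means a weaker inhibitor, a lower number a stronger inhibitor:
- Compound 1 `COc1cc(C(=O)c2ccc3[nH]ccc3c2)cc(OC)c1OC`: 88 nM
- Compound 2 `COc1cc(C(=O)c2ccc3c(ccn3C)c2)cc(OC)c1OC`: 11.2 nM
- Compound 3 `COc1cc(C(=O)c2ccc3c(ccn3CO)c2)cc(OC)c1OC`: 33 nM

Compound 3 holds the middle place of these three numbers, with compound 1 higher and compound 2 lower, both beyond the scatter. The next compound, compound 4 `COc1cc(C(=O)c2ccc3c(ccn3CC(=O)O)c2)cc(OC)c1OC`, keeps the shared core but has carboxy in place of hydroxy on a saturated chain carbon bound to an aromatic nitrogen.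

For the measured compounds named here, no measured step makes this exchange. The nearest evidence is a 2.9-fold higher number from compound 2 to compound 3 (0.47 log units; beyond the scatter), a modest rise from a change on that same chain carbon. The other two steps, a 7.9-fold lower number from compound 1 to compound 2 (0.90 log units; beyond the scatter) and a 2.7-fold lower number from compound 1 to compound 3 (0.43 log units; beyond the scatter), are also modest and show that the group on the aromatic nitrogen moves the number. Going by the values given here, on the strength of a 2.9-fold higher number from compound 2 to compound 3 (0.47 log units; beyond the scatter), a further modest rise is expected in this assay, though no measured compound carries carboxy, so the uncertainty is wide. The estimated value for compound 4 is 120 nM, within an expected range of 35 nM to 500 nM. The expected change is a 3.6-fold higher number from compound 3 to compound 4 (0.56 log units; beyond the scatter).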

Compound 4, half-maximal inhibitory concentration: 396 nM
Beside the measured number, compound 4's estimate is 3.3-fold (0.52 log units) below it, within the range that was stated.
By their numbers in this assay, from the lowest: compound 2; then compound 3; then compound 1; then compound 4.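

In this assay, carboxy in place of hydroxy on this saturated chain carbon is a large step (a 12-fold higher number from compound 3 to compound 4 (1.08 log units; beyond the scatter)), well beyond the modest rise seen when hydroxy replaced hydrogen at the same carbon (a 2.9-fold higher number from compound 2 to compound 3 (0.47 log units; beyond the scatter)). Against the methyl of compound 2 the rise is larger still (a 35-fold higher number from compound 2 to compound 4 (1.55 log units; beyond the scatter)). Carboxymethyl is also the only group shown that ends above hydrogen on the aromatic nitrogen (a 4.5-fold higher number from compound 1 to compound 4 (0.65 log units; beyond the scatter)), whereas methyl and hydroxymethyl both gave lower numbers than hydrogen, so the group at this place can move the number in either direction.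

No measurement shown gives a reason for this rise. Still open, as far as these compounds go, is how an amine, an amide or a longer chain ending in a carboxylic acid on the aromatic nitrogen would read in this assay.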